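The compounds below may be only part of what the source reports. "The series", "measured", "known", "first", "only" and "open" are said of these compounds alone.

Compound 1 `Cc1ccc2[nH]c(=O)c(-c3nc4cc([N+](=O)[O-])ccc4[nH]3)cc2c1` gives > 100000 nM in a functional assay on BEL-7404 cells for cytotoxicity against BEL-7404 tumor cell line (Homo sapiens), read by MTT assay, with a stated time of 48 h; a higher number here means a weaker inhibitor, a lower number a stronger inhibitor.
Compound 2 `Cc1ccc2[nH]c(=O)c(-c3nc4cc(C)c(C)cc4[nH]3)cc2c1` gives > 100000 nM in this assay.
Compound 3 `COc1ccc2[nH]c(=O)c(-c3nc4cc([N+](=O)[O-])ccc4[nH]3)cc2c1` gives > 100000 nM in this assay.

Compound 1 stands at a limit of this assay, not at a measured number, and the same limit is all that is known for the other two compounds. Among the compounds with values here, the only step among them that changes a single place, a step that the two limits leave unreadable from compound 1 to compound 3, is therefore unreadable: the two values that frame it are both limits, and the size of the step cannot be taken from them. Nothing in the shown data separates any one of the three compounds from the others.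

Compound 4 `Cc1ccc2[nH]c(=O)c(-c3nc4cc(Br)ccc4[nH]3)cc2c1` differs from compound 1 in one place: bromo in place of nitro on an aromatic carbon. Within the data shown here, no measured step among the three compounds bears on a bromo for nitro exchange, and none of the measured steps is readable at all. Among the measured compounds shown here, the only guide is the limit of > 100000 nM in this assay, at which 3 of the 3 values shown sit, which says that every value shown sits at the same limit. Compound 4 is therefore expected to remain at or near that limit, estimated at 100000 nM with a range from 30000 nM to 300000 nM. The expected step is a number no higher from compound 1 to compound 4 (the limit leaves the size open), not beyond the scatter.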

Compound 4, half-maximal inhibitory concentration: > 100000 nM
Compound 4 gave a limit, no number; the forecaster's own chance of this, stated with the estimate: 75%; the middle value sits exactly at the limit.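

No new step can be read between compound 1 and compound 4 in this assay because each gives a limit and not a number: the limit of > 100000 nM in this assay, at which 4 of the 4 values shown sit. The compounds shown leave open whether any group on the shared core would give a measured number in this assay, and how bromo and nitro compare there.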